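Replacing the hydroxy-bearing aryl group of compound 2

The compounds below may be only part of what the source reports. "The series", "measured", "known", "first", "only" and "open" are said of these compounds alone.

In a functional assay on EKVX cells (Homo sapiens) for inhibition, read by sulforhodamine B assay, with a stated time of 48 h (a lower number here means a stronger inhibitor of growth, a higher number a weaker inhibitor of growth), compound 1 (`Cc1ccc(C2=NN(c3ccc(S(C)(=O)=O)cc3)C(=O)CC2)cc1`) gives 3020 nM and compound 2 (`Cc1cc(O)ccc1C1=NN(c2ccc(S(C)(=O)=O)cc2)C(=O)CC1`) gives 57900 nM as its value, the higher of the two numbers and so the weaker growth inhibitor of the pair. Compound 3 (`CCc1ccc(C2=NN(c3ccc(S(C)(=O)=O)cc3)C(=O)CC2)cc1`) is now set against compound 2, and the change is 4-ethylphenyl in place of 4-hydroxy-2-methylphenyl on a carbon with a double bond to nitrogen on the shared core. Among the compounds with values here, only one measured step bears on this: a 19-fold higher number from compound 1 to compound 2 (1.28 log units; beyond the scatter) on putting 4-hydroxy-2-methylphenyl in place of 4-methylphenyl, a large step beyond the scatter. Compound 3 gives up that 4-hydroxy-2-methylphenyl group for a 4-ethylphenyl group, so a return towards compound 1 at 3020 nM is expected. Within the data shown here, no measured compound shows what an ethyl group does in place of a methyl group, which widens the range. The expected change is a 19-fold lower number from compound 2 to compound 3 (1.29 log units; beyond the scatter) towards a lower number, close in size to the measured step. For compound 3 the estimated value is 3000 nM with an expected range of 1200 nM to 9000 nM as its likely span.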

Compound 3, concentration for 50% growth inhibition: 4190 nM
For compound 3 the middle estimate is 1.4-fold (0.15 log units) below the measured one, and the stated range covers the measured number.
By their numbers in this assay, from the lowest: compounds 1 and 3 (each within the scatter of the next); then compound 2.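

In this assay, the step of a 1.4-fold higher number from compound 1 to compound 3 (0.14 log units; within the scatter) stays within the scatter, so lengthening the 4-methylphenyl group to the 4-ethylphenyl group at this position, on a carbon with a double bond to nitrogen, gives no change that can be read. The large step of a 14-fold lower number from compound 2 to compound 3 (1.14 log units; beyond the scatter) adds a second compound with a para-free comparison to compound 2, and the weak growth inhibition of compound 2 is now set against two neighbours rather than one. Compound 1 and compound 3 both carry a single alkyl group on the phenyl ring and no hydroxy group, and both sit far from compound 2, so the large gap seen in the step of a 19-fold higher number from compound 1 to compound 2 (1.28 log units; beyond the scatter) is not peculiar to compound 1.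

Compound 2 differs from the other two in both its hydroxy group and its methyl group, so a 4-hydroxyphenyl or a 2-methylphenyl group at this position would be needed to separate the two, and a longer chain such as 4-propylphenyl would show how far the flat result from methyl to ethyl extends. Why the 4-hydroxy-2-methylphenyl group gives so much weaker a number cannot be said from what is at hand, as nothing measured beyond these values bears on it.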